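Ethyl on the ring nitrogen: a cytotoxicity forecast

This account rests on a few compounds, and the source may have more. Where it says the series, first, only, none or still open, it means among the compounds named here.

The measured compounds in an ADME assay on MT4 cells (Homo sapiens) for cytotoxicity, read by MTT assay, with a stated time of 4 days (a lower number here means that less compound is tolerated, a higher number that more compound is tolerated), are:
Compound 1 `N#Cc1ccc(Nc2nc(N)nc(Oc3cccc4ccccc34)n2)cc1` gives 39100 nM.
Compound 2 `CNc1nc(Nc2ccc(C#N)cc2)nc(Oc2ccc(Cl)c3ccccc23)n1` gives 197000 nM.
Compound 3 `N#Cc1ccc(Nc2nc(N)nc(Oc3ccc(Cl)c4ccccc34)n2)cc1` gives 237000 nM.

Compound 3 carries the top number of the three, but the picture is uneven. The step of a 6.1-fold higher number from compound 1 to compound 3 (0.78 log units; beyond the scatter) is beyond the scatter, so compound 3 is clearly better tolerated than compound 1. The step of a 1.2-fold higher number from compound 2 to compound 3 (0.08 log units; within the scatter), by contrast, lies within the scatter, so compound 2 and compound 3 cannot be told apart on these numbers.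

Compound 4 `CCNc1nc(Nc2ccc(C#N)cc2)nc(Oc2ccc(Cl)c3ccccc23)n1` differs from compound 3 by one change: ethyl in place of hydrogen on a nitrogen on an aromatic ring. Among the measured compounds shown here, only one measured step touches this position, the step from compound 2 to compound 3, where a methyl on that same nitrogen against a hydrogen made no difference beyond the scatter. Ethyl is one carbon longer than methyl, and nothing measured here speaks to that extra carbon, so the expectation rests on the methyl case alone. The step expected in this assay is therefore a 1.2-fold lower number from compound 3 to compound 4 (0.07 log units; within the scatter), none beyond the scatter. Compound 4 is estimated at 200000 nM, with a range from 95000 nM to 420000 nM.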

Compound 4, half-maximal cytotoxic concentration: 208000 nM
Beside the measured number, compound 4's estimate is 1.0-fold (0.02 log units) below it; the measured number falls inside the stated range.
By their numbers in this assay, from the lowest: compound 1; then compounds 2, 4 and 3 (each within the scatter of the next).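

Until now, this nitrogen had only shown that methyl and hydrogen could not be told apart in this assay on the core of compound 3. Ethyl extends that comparison by one more carbon, with a 1.1-fold lower number from compound 3 to compound 4 (0.06 log units; within the scatter) against hydrogen and a 1.1-fold higher number from compound 2 to compound 4 (0.02 log units; within the scatter) against methyl on the same nitrogen. Hydrogen, methyl and ethyl therefore all lie within the scatter of one another here, so neither the first carbon nor the second gives a step that these numbers can resolve, and no measurement is available to account for this.

Going by these compounds, what remains open is whether the same holds for a longer chain such as butyl, a small ring such as cyclopropyl, or a chain ending in an amine or a carboxylic acid on this nitrogen. All of these steps also sit on the chloro-bearing core, so the compounds shown do not say whether ethyl in place of hydrogen would give a similar result on the core of compound 1, which lacks the chloro group.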